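Aryl ring swap at the enone: fluorophenyl analogue

A few compounds are considered here, and "the series" means these few. Any claim that something is new, unique, unknown or untested is made for them only; others in the source may bear on it.

The series shares a sulfonylurea-bearing core with a varied aryl ring on the enone chain. Among the measured compounds shown here, compound 3 `CCOc1cc(/C=C/C(=O)c2ccccc2NC(=O)NS(=O)(=O)c2ccc(C)cc2)ccc1O` gives 19.2 ug/mL in an ADME assay on the whole organism for cytotoxicity, with Artemia salina as the target, with a stated time of 24 h (on this read-out lower numbers stand for an effect already at smaller amounts and higher numbers for an effect only at larger amounts of compound), the lowest of the three numbers so far; compound 1 `COc1cccc(/C=C/C(=O)c2ccccc2NC(=O)NS(=O)(=O)c2ccc(C)cc2)c1` gives 23.2 ug/mL, a gap that stays within the scatter, while compound 2 `Cc1ccc(S(=O)(=O)NC(=O)Nc2ccccc2C(=O)/C=C/c2cccc(O)c2)cc1` gives 39.3 ug/mL, the only measured partner beyond the scatter from compound 3. The next compound, compound 4 `Cc1ccc(S(=O)(=O)NC(=O)Nc2ccccc2C(=O)/C=C/c2ccc(F)cc2)cc1`, differs from compound 3 by 4-fluorophenyl in place of 3-ethoxy-4-hydroxyphenyl on a double-bonded chain carbon bound to a double-bonded chain carbon.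

For the measured compounds named here, two measured steps bear on changes at this aryl ring: a 1.2-fold lower number from compound 1 to compound 3 (0.08 log units; within the scatter) and a 2.0-fold lower number from compound 2 to compound 3 (0.31 log units; beyond the scatter). Both are small, one inside and one just outside the scatter, so varying the oxygen substituents on this ring has moved this assay only modestly. Going by the values given here, no measured step covers a ring carrying fluorine and no oxygen at all, so that part of the change is uncharted. The working expectation is therefore a step of a 1.4-fold higher number from compound 3 to compound 4 (0.13 log units; within the scatter) in this assay, most likely not beyond the scatter, with no firm direction. Compound 4 is estimated at 26 ug/mL in this assay, with a plausible range from 12 ug/mL to 55 ug/mL.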

Compound 4, concentration for half-maximal effect: 3.96 ug/mL
Beside the measured number, compound 4's estimate is 6.6-fold (0.82 log units) above it, outside the stated range (below it).
By their numbers in this assay, from the lowest: compound 4; then compounds 3, 1 and 2 (each within the scatter of the next, the first and the last beyond it).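

At the double-bonded chain carbon bound to a double-bonded chain carbon, 4-fluorophenyl produces the largest movement yet seen in this assay: a 4.8-fold lower number from compound 3 to compound 4 (0.69 log units; beyond the scatter), alongside a 5.9-fold lower number from compound 1 to compound 4 (0.77 log units; beyond the scatter) and a 9.9-fold lower number from compound 2 to compound 4 (1.00 log units; beyond the scatter), which places compound 4 apart from all three oxygen-bearing analogues. This position can therefore shift the read-out well beyond what exchanges among the oxygen-bearing rings showed, although the change removes the oxygen substituents and introduces fluorine in one step, so the two contributions cannot be separated. No measurement available here gives a cause for the step.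

Still open, on these data alone, is whether fluorine itself matters or whether the absence of the oxygen substituents is enough, a question that an unsubstituted phenyl, 4-chlorophenyl or 4-aminophenyl ring at this place would address. Also open is whether the lower number of compound 4 carries over to any other read-out, as the compounds shown here are compared in this assay alone.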